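This account rests on a few compounds, and the source may have more. Where it says the series, first, only, none or still open, it means among the compounds named here.

Measured compounds:
compound 1, `CCCSc1nc(N/N=C/c2ccc(Cl)cc2)c2nnn(Cc3ccccc3)c2n1`, with > 64000 nM in a functional assay on MCF7 cells (Homo sapiens) for antiproliferative activity, read by MTT assay, with a stated time of 72 h; on this read-out lower numbers stand for stronger inhibition and higher numbers for weaker inhibition
compound 2, `C#CCSc1nc(N/N=C(\C)c2ccccc2O)c2nnn(Cc3ccccc3)c2n1`, with 11300 nM in this assay
compound 3, `CCCSc1nc(N/N=C/c2cc(OC)c(OC)c(OC)c2)c2nnn(Cc3ccccc3)c2n1`, with > 64000 nM in this assay

In this assay compound 1 gives only a limit of the assay, > 64000 nM, not a number. Compound 3 likewise stops at a limit, > 64000 nM. Compound 2 alone gives a number, 11300 nM. Going by the values given here, compound 1 therefore stands at the limit of > 64000 nM in this assay, at which 2 of the 3 values shown sit, with no measured step from any neighbour that differs in one place.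

Compound 4, `CCCSc1nc(N/N=C/c2ccccc2)c2nnn(Cc3ccccc3)c2n1`, differs from compound 1 as follows: hydrogen in place of chloro on an aromatic carbon. Nothing measured isolates this change. No step beyond the scatter in this assay is expected from it, so compound 4 is expected to remain at the limit, giving about 70000 nM (range 20000 nM to 200000 nM). The expected step is a step that the limit leaves unreadable from compound 1 to compound 4.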

Compound 4, half-maximal inhibitory concentration: > 64000 nM
Compound 4 was reported as a limit (the forecaster's own chance of this, stated with the estimate: 75%); the middle value lies beyond the limit too.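

Compound 1 and compound 4 both stop at a limit, so no step can be read between them: the limit of > 64000 nM in this assay, at which 3 of the 4 values shown sit.

As far as these compounds go, whether hydrogen in place of chloro on an aromatic carbon changes activity in this assay stays open.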